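Methoxy for chloro in two pairs: solubility notes

The source may report more compounds than this note shows. Statements on the series, on what has been measured and on what is new or still open speak of the compounds shown alone.

Compound 1 `O=C(Nc1ccc([N+](=O)[O-])cc1Cl)c1ccc(Cl)cc1O` and compound 2 `COc1ccc(C(=O)Nc2ccc([N+](=O)[O-])cc2Cl)c(O)c1` share one core; compound 3 `O=C(Nc1ccc(Cl)cc1)c1cc(Cl)ccc1O` and compound 4 `COc1ccc(NC(=O)c2cc(Cl)ccc2O)cc1` share another. The difference between the two cores is not broken down here. In a physicochemical assay for solubility (on this read-out higher numbers stand for higher solubility and lower numbers for lower solubility), compound 1 gives 1.1 ug/mL. For compound 2 this assay reports only a limit, < 1 ug/mL. For compound 3 this assay likewise reports only a limit, < 1 ug/mL. Two of the three values sit at the limit of < 1 ug/mL in this assay, at which 2 of the 3 values shown sit. The change methoxy in place of chloro on an aromatic carbon gives an at least 1.1-fold lower number from compound 1 to compound 2 (0.04 log units; that floor lies within the scatter). The same kind of change is made as methoxy in place of chloro on an aromatic carbon; the first place is meta to a hydroxy group (1 heavy atom), which is not stated for the second. Compound 4 is expected to show a step that the limit leaves unreadable from compound 3 to compound 4, resting on the step of an at least 1.1-fold lower number from compound 1 to compound 2 (0.04 log units; that floor lies within the scatter). The estimate for compound 4 is 0.8 ug/mL, within 0.3 ug/mL to 2.5 ug/mL.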

Compound 4, solubility: 2.8 ug/mL
Compound 4: the middle estimate sits 3.5-fold (0.54 log units) below what was measured; measured number above the stated range.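

In this assay, methoxy in place of chloro gives an at least 2.8-fold higher number from compound 3 to compound 4 (0.44 log units; beyond the scatter), against an at least 1.1-fold lower number from compound 1 to compound 2 (0.04 log units; that floor lies within the scatter) in the other core. The lower number seen in the core of compound 1 therefore does not carry over to the core of compound 3, and only the higher-number step lies beyond the scatter. Compound 2 and compound 3 each have only a limit, so neither step has a known size and no reason for the difference between the cores can be read: the limit of < 1 ug/mL in this assay, at which 2 of the 4 values shown sit.

Two pairs cannot settle whether the direction follows the core or the place of the change. Also open, as far as these compounds go, is how an amine, a carboxylic acid or a longer chain in that place would read in this assay.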